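A few compounds are considered here, and "the series" means these few. Any claim that something is new, unique, unknown or untested is made for them only; others in the source may bear on it.

Values so far in an ADME assay on MT4 cells (Homo sapiens) for cytotoxicity, read by MTT assay; on this read-out higher numbers stand for lower toxicity in this test and lower numbers for higher toxicity in this test:
compound 1 `O=C1c2ccccc2C(=O)N1CCOC(=S)N(C(=O)c1cccc([N+](=O)[O-])c1)c1ccc(Cl)cc1` gives 18000 nM
compound 2 `O=C1c2ccccc2C(=O)N1CCOC(=S)N(C(=O)c1ccc(F)cc1F)c1ccc(Cl)cc1` gives 52000 nM
compound 3 `O=C1c2ccccc2C(=O)N1CCOC(=S)N(C(=O)c1cc(Cl)cc(Cl)c1)c1ccc(Cl)cc1` gives 32000 nM

The value of compound 3 lies within the scatter of both other measured compounds, so it does not stand apart from either. The next compound, compound 4 `Cc1cc(C(=O)N(C(=S)OCCN2C(=O)c3ccccc3C2=O)c2ccc(Cl)cc2)ccc1Br`, has 4-bromo-3-methylphenyl in place of 3,5-dichlorophenyl on a carbonyl carbon, with the rest of the structure unchanged: 4-bromo-3-methylphenyl in place of 3,5-dichlorophenyl on a carbonyl carbon. Within the data shown here, the 4-bromo-3-methylphenyl group has no measured precedent in this set.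

All three measured steps exchange the group at this same place, so all three bear on the change. Two stay within the scatter: a 1.8-fold higher number from compound 1 to compound 3 (0.25 log units; within the scatter) and a 1.6-fold lower number from compound 2 to compound 3 (0.21 log units; within the scatter). Only a 2.9-fold higher number from compound 1 to compound 2 (0.46 log units; beyond the scatter) goes beyond it, and that step is modest. Three compounds are too few to show a trend with substitution, and they give no direction for the new group.

No step beyond the scatter is therefore expected in this assay, and neither direction is favoured. The expected step is a 1.1-fold lower number from compound 3 to compound 4 (0.03 log units; within the scatter) and it is only an estimate. For compound 4 the estimated value is 30000 nM, with an expected range from 14000 nM to 62000 nM.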

Compound 4, half-maximal cytotoxic concentration: 18000 nM
The estimate for compound 4 lay 1.7-fold (0.22 log units) above the measured number; low and high end bracket the measured number.
By their numbers in this assay, from the lowest: compounds 1, 4, 3 and 2 (each within the scatter of the next, the first and the last beyond it).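

In this assay, 4-bromo-3-methylphenyl on this carbonyl carbon stays within the scatter of the 3,5-dichlorophenyl group, with a 1.8-fold lower number from compound 3 to compound 4 (0.25 log units; within the scatter), and also of the 3-nitrophenyl group, with no change at the digits printed from compound 1 to compound 4 (within the scatter). The 2,4-difluorophenyl group now stands apart from two of the other three groups at this place, with a 2.9-fold lower number from compound 2 to compound 4 (0.46 log units; beyond the scatter), a modest step that matches in size the one already seen against 3-nitrophenyl, while the gap to 3,5-dichlorophenyl remains within the scatter. Across these four compounds, the exchange of one substituted phenyl for another therefore gives at most modest steps, and nothing available explains why the 2,4-difluorophenyl group separates from two of the others.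

Going by these compounds, all four compounds carry a substituted phenyl at this place, so the effect of an amine or a carboxylic acid on that ring, or of a plain alkyl chain in its stead, remains open. On these data alone, whether changes elsewhere in the shared core would give steps of a similar size also stays open.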